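A few compounds are considered here, and "the series" means these few. Any claim that something is new, unique, unknown or untested is made for them only; others in the source may bear on it.

Measured in a functional assay on MCF7 cells (Homo sapiens) for cytotoxicity, read by MTT assay, with a stated time of 24 h; a lower number here means a stronger inhibitor, a higher number a weaker inhibitor:
- compound 1 `COc1ccc(/C=C(\C#N)C(=O)N/N=C(\C)c2c(O)c3ccc(O)cc3oc2=O)cc1`: 8940 nM
- compound 2 `C/C(=N\NC(=O)/C(C#N)=C/c1ccc(N(C)C)cc1)c1c(O)c2ccc(O)cc2oc1=O`: 3420 nM
- compound 3 `C/C(=N\NC(=O)/C(C#N)=C/c1cccc([N+](=O)[O-])c1)c1c(O)c2ccc(O)cc2oc1=O`: 16400 nM

Compound 3 cannot be told apart from compound 1, with a 1.8-fold higher number from compound 1 to compound 3 (0.26 log units; within the scatter). Compound 2 lies clearly lower, with a 4.8-fold higher number from compound 2 to compound 3 (0.68 log units; beyond the scatter). Compound 4 `C/C(=N\NC(=O)/C(C#N)=C/c1ccccc1[N+](=O)[O-])c1c(O)c2ccc(O)cc2oc1=O` keeps the same atoms joined differently: 2-nitrophenyl in place of 3-nitrophenyl on a double-bonded chain carbon bound to a double-bonded chain carbon, with 2-nitrophenyl in place of 3-nitrophenyl on a double-bonded chain carbon bound to a double-bonded chain carbon. Among the measured compounds shown here, no measured step isolates this change. The nearest evidence is the exchange of whole aryl groups, which was modest at most, so no shift beyond the scatter is expected in this assay, and no direction can be favoured. The expected step is a 1.2-fold lower number from compound 3 to compound 4 (0.07 log units; within the scatter). For compound 4 the estimated value is 14000 nM, with an expected range of 6000 nM to 30000 nM.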

Compound 4, half-maximal inhibitory concentration: 9180 nM
For compound 4 the middle estimate is 1.5-fold (0.18 log units) above the measured one; low and high end bracket the measured number.
By their numbers in this assay, from the lowest: compound 2; then compounds 1, 4 and 3 (each within the scatter of the next).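

In this assay, 2-nitrophenyl in place of 3-nitrophenyl at this place on a double-bonded chain carbon gives a step within the scatter (a 1.8-fold lower number from compound 3 to compound 4 (0.25 log units; within the scatter)), so the two nitro isomers cannot be told apart. Compound 4 also cannot be told apart from compound 1 (a 1.0-fold higher number from compound 1 to compound 4 (0.01 log units; within the scatter)), whereas 4-(dimethylamino)phenyl remains distinct from 2-nitrophenyl (a 2.7-fold higher number from compound 2 to compound 4 (0.43 log units; beyond the scatter)). No measurement shown here offers an explanation for these results. On these data alone, whether 4-nitrophenyl would match its two isomers remains open, as does whether an aryl group carrying a primary amine or a carboxylic acid would give a lower number than compound 2.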